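Moving a Trifluoromethyl Group and Its Effect on Cell Potency

The source may hold more compounds than are shown below. What is called first, only, known or untested is meant among the compounds shown, and "the series" means these compounds.

Compound 1 `CC(O)(COc1cccc(C(F)(F)F)c1)C(=O)Nc1ccc(S(F)(F)(F)(F)F)cc1` and compound 3 `CC(O)(COc1cccc(C(F)(F)F)c1)C(=O)Nc1cccc(S(F)(F)(F)(F)F)c1` are built from the same atoms, joined differently; the difference between the two cores is not broken down here. In a functional assay on VCaP cells (Homo sapiens) for antiproliferative activity, read by propidium iodide staining, with a stated time of 96 h (a higher number here means a weaker inhibitor, a lower number a stronger inhibitor), compound 1 gives 24700 nM, and compound 3 gives 22500 nM. These two numbers lie within the usual scatter of each other, so the two compounds cannot be told apart by this measurement.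

Compound 2 `CC(O)(COc1ccccc1C(F)(F)F)C(=O)Nc1ccc(S(F)(F)(F)(F)F)cc1` arises from compound 1 through one change: 2-(trifluoromethyl)phenyl in place of 3-(trifluoromethyl)phenyl on an oxygen on a saturated carbon. This change made an 8.0-fold lower number from compound 1 to compound 2 (0.90 log units; beyond the scatter), so that compound 2 gives 3100 nM in this assay.

Compound 4 `CC(O)(COc1ccccc1C(F)(F)F)C(=O)Nc1cccc(S(F)(F)(F)(F)F)c1` has not yet been measured. It arises from compound 3 through (2-(trifluoromethyl)phenyl in place of 3-(trifluoromethyl)phenyl on an oxygen on a saturated carbon), the same change as that from compound 1 to compound 2, made at the same place. Because the step of an 8.0-fold lower number from compound 1 to compound 2 (0.90 log units; beyond the scatter) lay beyond the scatter, and because compound 3 gives 22500 nM within the scatter of compound 1, a step of similar size is expected from compound 3 to compound 4, namely a 7.5-fold lower number from compound 3 to compound 4 (0.88 log units; beyond the scatter). Only one earlier example of this change exists among these compounds, so the expectation rests on a single step and carries a wide margin. Compound 4 is estimated to give 3000 nM in this assay, with a likely range from 1200 nM to 8000 nM.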

Compound 4, half-maximal inhibitory concentration: 36700 nM
The estimate for compound 4 lay 12-fold (1.09 log units) below the measured number; measured number above the stated range.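

On the core of compound 3, putting 2-(trifluoromethyl)phenyl in place of 3-(trifluoromethyl)phenyl on the oxygen gave a 1.6-fold higher number from compound 3 to compound 4 (0.21 log units; within the scatter) in this assay, so this measurement cannot tell compound 3 and compound 4 apart. The clear gain seen on the core of compound 1 therefore did not carry over to the core of compound 3, and the two results differ by more than repeated measurements would explain: the same change on two cores in this assay, an 8.0-fold lower number (0.90 log units; beyond the scatter) from compound 1 to compound 2 and a 1.6-fold higher number (0.21 log units; within the scatter) from compound 3 to compound 4, 13-fold (1.11 log units) apart, beyond the scatter of two such steps. This shows that, for these two cores, the effect of moving the trifluoromethyl group depends on the core that carries it, but with a single pair of compounds on each core, it does not show why the results differ or what the same change would do on any other core.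

From the compounds shown here alone, it remains open whether a different group in place of trifluoromethyl, such as a nitrile or a chlorine atom, would respond to the change of core as compound 1 and compound 2 do or as compound 3 and compound 4 do. The compounds shown also leave open what would happen if an amine took the place of the oxygen on the saturated carbon.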